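Swapping bromo for chloro on the benzoyl ring of compound 1

The compounds below may be only part of what the source reports. "The series", "measured", "known", "first", "only" and "open" are said of these compounds alone.

Measured compounds:
compound 1, `Cc1ccc(S/C(=C/c2ccc(Cl)cc2)C(=O)c2ccc(Br)cc2)cc1`, 10000 nM
compound 2, `Cc1ccc(S/C(=C/c2ccc(Oc3ccccc3)cc2)C(=O)c2ccc(Br)cc2)cc1`, 1000 nM
compound 3, `O=C(/C(=C\c1ccc(Cl)cc1)Sc1ccc(Br)cc1)c1ccc(Br)cc1`, 1000 nM

Of the compounds shown here, three sharing one core have been tested in a functional assay on DU-145 cells (Homo sapiens) for inhibition, read by trypan blue exclusion, with a stated time of 96 h; a lower number here means a stronger inhibitor of growth, a higher number a weaker inhibitor of growth. Compound 1 gives the highest number of the three, so it is the weakest growth inhibitor shown. Two single changes from it have been measured: a 10-fold lower number from compound 1 to compound 2 (1.00 log units; beyond the scatter), and a 10-fold lower number from compound 1 to compound 3 (1.00 log units; beyond the scatter). Each of these moves to a lower number by the same margin, and both lie beyond the scatter.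

The unmeasured compound 4, `Cc1ccc(S/C(=C/c2ccc(Cl)cc2)C(=O)c2ccc(Cl)cc2)cc1`, differs from compound 1 in one place: chloro in place of bromo on an aromatic carbon. The same difference, cut one bond further out, reads 4-bromophenyl to 4-chlorophenyl.

Neither measured step bears on this change. The step from compound 1 to compound 2 alters a different ring, and the step from compound 1 to compound 3 changes methyl to bromo rather than bromo to chloro. Among the measured compounds shown here, no pair of measured compounds shows the effect of exchanging these two halogens anywhere on the core. The expectation for compound 4 therefore rests on the small size of the change alone, and a step within the scatter, in no firm direction, is expected: no change at the digits printed from compound 1 to compound 4 (within the scatter). Compound 4 is estimated at 10000 nM, with a range from 4000 nM to 25000 nM.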

Compound 4, concentration for 50% growth inhibition: 10000 nM
Estimate against measurement, compound 4: no gap at the digits printed; the measured number falls inside the stated range.
By their numbers in this assay, from the lowest: compounds 2 and 3 (each within the scatter of the next); then compounds 1 and 4 (each within the scatter of the next).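

In this assay, the exchange of bromo for chloro on the benzoyl ring gives no change at the digits printed from compound 1 to compound 4 (within the scatter) and is the only exchange of these two halogens among the compounds shown. At this place, para to a large group, the assay does not separate the 4-bromophenyl from the 4-chlorophenyl, whereas changes elsewhere on the core did shift the number, as in a 10-fold lower number from compound 1 to compound 2 (1.00 log units; beyond the scatter) on the ring carrying the chloro group and a 10-fold lower number from compound 1 to compound 3 (1.00 log units; beyond the scatter) on the ring carrying the methyl group. The result therefore marks this one halogen exchange as silent on the core of compound 1, but no measurement accompanies it that could explain why.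

The compounds shown leave open whether a group of another kind at this place, such as an amine, a carboxylic acid or a longer chain, would move the number in either direction. They also leave open whether the same halogen exchange would remain within the scatter on the cores of compound 2 and compound 3, which sit at lower numbers.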